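Replacing the Acid of Compound 1 with an Amine-Bearing Amide

The source may hold more compounds than are shown below. What is called first, only, known or untested is meant among the compounds shown, and "the series" means these compounds.

Measured compounds:
compound 1 `O=C(O)CCC(=O)OCCCCCCSc1ccc([N+](=O)[O-])c2nonc12` gives 160 nM
compound 2 `O=C(CCC(=O)OCCCCCCSc1ccc([N+](=O)[O-])c2nonc12)Nc1ccc(C(F)(F)F)cc1` gives 90 nM
compound 3 `O=C(CCC(=O)OCCCCCCSc1ccc([N+](=O)[O-])c2nonc12)Nc1ccc(F)c(Cl)c1` gives 470 nM

The three measured compounds share one core and differ only at a carbonyl carbon of the chain. In an assay on isolated protein for inhibition of glutathione S-transferase Mu 2 (Homo sapiens), with a stated time of 10 min (a higher number here means a weaker inhibitor, a lower number a stronger inhibitor), compound 1 stands second highest of the three numbers. Its nearest neighbour is compound 2, reached by a 1.8-fold lower number from compound 1 to compound 2 (0.25 log units; within the scatter), and its furthest is compound 3, reached by a 2.9-fold higher number from compound 1 to compound 3 (0.47 log units; beyond the scatter). Between the two amides the gap is a 5.2-fold higher number from compound 2 to compound 3 (0.72 log units; beyond the scatter).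

Compound 4 `O=C(CCC(=O)OCCCCCCSc1ccc([N+](=O)[O-])c2nonc12)NCCN1CCCC1` has not been measured. It differs from compound 1 as follows: (2-(pyrrolidin-1-yl)ethyl)amino in place of hydroxy on a carbonyl carbon. Among the compounds with values here, the steps that bear on this change are those from compound 1 to compound 2 and from compound 1 to compound 3, since both also replace hydroxy by an amino group on the same carbonyl carbon; one lies within the scatter and one is a modest move beyond it, in opposite directions. Within the data shown here, no measured step involves the (2-(pyrrolidin-1-yl)ethyl)amino group itself, so the expectation rests on that spread alone. In this assay compound 4 is therefore expected to show no step beyond the scatter, a 1.3-fold higher number from compound 1 to compound 4 (0.10 log units; within the scatter), with a wide band of uncertainty. Compound 4 is estimated at 200 nM, within a range from 70 nM to 600 nM.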

Compound 4, half-maximal inhibitory concentration: 200 nM
The estimate for compound 4 equals the measured number at the digits printed; the range from low to high includes it.
By their numbers in this assay, from the lowest: compounds 2, 1 and 4 (each within the scatter of the next, the first and the last beyond it); then compound 3.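

In this assay, (2-(pyrrolidin-1-yl)ethyl)amino on this carbonyl carbon brings a non-aromatic ring and no aromatic group to the amide nitrogen, yet the acid-to-amide step stays within the scatter, a 1.3-fold higher number from compound 1 to compound 4 (0.10 log units; within the scatter). Set against the two aryl amides, the new compound gives a 2.4-fold lower number from compound 3 to compound 4 (0.37 log units; beyond the scatter) and a 2.2-fold higher number from compound 2 to compound 4 (0.35 log units; beyond the scatter), so all three amides differ beyond the scatter from at least one other amide, and what the amide nitrogen carries matters at this position more than the amide as such. No measurement shown here explains these differences.

The compounds shown leave open whether the pyrrolidine ring itself contributes, as a morpholine or piperidine ring, or a plain butyl chain on the amide nitrogen, would test. They also leave open how a propyl chain in place of the ethyl would read.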